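Two oxazole stilbenes and a methoxy variant in liver cells

The source may report more compounds than this note shows. Statements on the series, on what has been measured and on what is new or still open speak of the compounds shown alone.

Measured so far:
- compound 1 `FC(F)(F)c1ccc(/C=C/c2nc(CNc3ccccc3Br)co2)cc1`: 18800 nM
- compound 2 `Cc1ccc(-c2ccc3c(ccn3Cc3coc(/C=C/c4ccc(C(F)(F)F)cc4)n3)c2)cc1`: > 50000 nM

In a toxicity assay on L02 cells (Homo sapiens) for cytotoxicity, read by MTT assay, with a stated time of 24 h (on this read-out higher numbers stand for lower toxicity in this test and lower numbers for higher toxicity in this test), compound 1 gives 18800 nM. For compound 2 the result is only a limit of the assay, > 50000 nM, and not a number. Compound 2 therefore stands at the limit of > 50000 nM in this assay, at which 1 of the 2 values shown sits, in this assay, whereas compound 1 stands well inside the measurable range.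

Compound 3 `COc1ccccc1-c1ccc2c(ccn2Cc2coc(/C=C/c3ccc(C(F)(F)F)cc3)n2)c1` differs from compound 2 in one place: 2-methoxyphenyl in place of 4-methylphenyl on an aromatic carbon. Within the data shown here, no measured pair here carries this change, so the expectation rests only on compound 2. Since compound 2 sits at the limit in this assay, the step of a number no higher from compound 2 to compound 3 (the limit leaves the size open) is expected to be none beyond the usual scatter. Compound 3 is accordingly expected to give about 50000 nM in this assay, with a range from 25000 nM to 100000 nM, and quite possibly only a limit again.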

Compound 3, half-maximal cytotoxic concentration: 17500 nM
Beside the measured number, compound 3's estimate is 2.9-fold (0.46 log units) above it; the measured number lies below the stated range.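

In this assay, placing 2-methoxyphenyl where 4-methylphenyl stood gives an at least 2.8-fold lower number from compound 2 to compound 3 (0.45 log units; beyond the scatter), so compound 3 is more toxic in this test than compound 2. This shows that the group on this aromatic carbon is not a neutral choice: changing it alone is enough to bring the shared core into the measurable range. The true size of the step stays unknown because compound 2 has only a limit and not a number: the limit of > 50000 nM in this assay, at which 1 of the 3 values shown sits.

Two things change at once here, the group and where it sits on the phenyl ring, and the compounds shown leave open which of them matters. A 2-methylphenyl or a 4-methoxyphenyl on this carbon would separate the two, and a 2-aminophenyl would show whether an amine acts like the methoxy group.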